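Working notes: from compound 2 to compound 4

A few compounds are considered here, and "the series" means these few. Any claim that something is new, unique, unknown or untested is made for them only; others in the source may bear on it.

Measured in a physicochemical assay for lipophilicity, using the shake flask method; on this read-out lower numbers stand for lower lipophilicity and higher numbers for higher lipophilicity:
- compound 1 `C[C@H](Oc1ccc(/C=C/C(=O)O)c(CC2CC2)c1)c1c(Cl)ccc(F)c1Cl`: 3.9
- compound 2 `C[C@H](Oc1ccc2ncc(-c3ccn(CCC(=O)O)n3)c(C3CC3)c2c1)c1c(Cl)cccc1Cl`: 2.7
- compound 3 `C[C@H](Oc1ccc2c(c1)c(C1CC1)c(/C=C/C(=O)O)c[n+]2[O-])c1c(Cl)ccc(F)c1Cl`: 1.7

Compound 2, at 2.7, is the second highest of the three. Compound 3 lies lower and compound 1 higher, both beyond the scatter.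

Compound 4 `C[C@H](Oc1ccc2ncc(/C=C/c3nn[nH]n3)c(C3CC3)c2c1)c1c(Cl)cccc1Cl` differs from compound 2 by a group of 7 heavy atoms (3 carbon, 4 nitrogen; one five-membered aromatic ring with 4 hetero atoms) in place of a group of 10 heavy atoms (6 carbon, 2 nitrogen, 2 oxygen; one five-membered aromatic ring with 2 hetero atoms), on an aromatic carbon. The change sits on an aromatic carbon ortho to a cyclopropyl group. For the measured compounds named here, no measured pair differs in one place only, so no direct precedent exists for this change. The estimated a number 0.30 log units lower from compound 2 to compound 4 (within the scatter) is a small fall, not expected to pass beyond the scatter. For compound 4 the estimated value is 2.4, with an expected range from 1.7 to 3.1.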

Compound 4, distribution coefficient: 4.3
Compound 4: the middle estimate sits 1.90 log units below what was measured; the whole stated range lies below it.
By their numbers in this assay, from the lowest: compound 3; then compound 2; then compound 1; then compound 4.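

At this position, on an aromatic carbon ortho to a cyclopropyl group, 2-(2H-tetrazol-5-yl)ethenyl in place of the group of 10 heavy atoms gives, in this assay, a number 1.60 log units higher from compound 2 to compound 4 (beyond the scatter). The read-out at this position is therefore highly sensitive to this change, even though both groups count the same hydrogen-bond donors and acceptors and carry no net charge. Nothing available explains the size of this step.

Going by these compounds, the whole group changes at once, so the separate shares of the double bond and the ring stay open. On these data alone, how a primary amide or an amine at this position would read in this assay is also open.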